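The compounds below may be only part of what the source reports. "The series", "measured", "known", "first", "only" and "open" are said of these compounds alone.

Series notes, inhibition of HeLa cell growth.

Three compounds have numbers in a functional assay on HeLa cells (Homo sapiens) for inhibition, read by MTT assay; on this read-out higher numbers stand for weaker inhibition and lower numbers for stronger inhibition. Compound 1 `CCCCCCCCn1cc(/C=C/C(=O)c2ccc(NC(=O)CN3CCN(c4ccccc4)CC3)cc2)nn1` gives 33800 nM. Compound 2 `O=C(CN1CCN(c2ccccc2F)CC1)Nc1ccc(C(=O)/C=C/c2cn(Cc3ccc(Br)cc3)nn2)cc1` gives 9120 nM. Compound 3 `COc1ccccc1N1CCN(CC(=O)Nc2ccc(C(=O)/C=C/c3cn(Cc4ccc(Br)cc4)nn3)cc2)CC1` gives 26400 nM, the second highest of the three numbers; its gap to compound 1 lies within the scatter, while the single-point step a 2.9-fold higher number from compound 2 to compound 3 (0.46 log units; beyond the scatter) is modest but beyond the scatter.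

Compound 4 `O=C(CN1CCN(c2ccccc2)CC1)Nc1ccc(C(=O)/C=C/c2cn(Cc3ccc(Br)cc3)nn2)cc1` is not yet measured. It differs from compound 3 in one place: hydrogen in place of methoxy on an aromatic carbon, the same change read one bond further out being 2-methoxyphenyl to phenyl. Compound 1 also carries the plain phenyl, but it differs from compound 4 in more than one place, so its value is only a loose reference. Among the measured compounds shown here, the one step that bears on the substituent at this carbon is a 2.9-fold higher number from compound 2 to compound 3 (0.46 log units; beyond the scatter): exchanging fluoro for methoxy raised the number, so removing the methoxy altogether may pull the number back toward that of compound 2, though no measured pair shows the methoxy-to-hydrogen change directly. For compound 4 the expectation is therefore a step of a 1.7-fold lower number from compound 3 to compound 4 (0.22 log units; within the scatter), toward a lower number, and an estimated value of 16000 nM in this assay, with a range from 6000 nM to 40000 nM.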

Compound 4, half-maximal inhibitory concentration: 79700 nM
For compound 4 the middle estimate is 5.0-fold (0.70 log units) below the measured one; the whole stated range lies below it.
By their numbers in this assay, from the lowest: compound 2; then compounds 3 and 1 (each within the scatter of the next); then compound 4.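

Removing the substituent at this carbon does not bring the number back toward that of the fluoro compound. In this assay the step from methoxy to hydrogen goes upward (a 3.0-fold higher number from compound 3 to compound 4 (0.48 log units; beyond the scatter)), and the step from fluoro to hydrogen is larger (an 8.7-fold higher number from compound 2 to compound 4 (0.94 log units; beyond the scatter)), so the three compounds with the 4-bromophenyl group run fluoro, then methoxy, then hydrogen, from the lowest number to the highest. With the plain phenyl held fixed, the other end of the molecule also moves the number (a 2.4-fold higher number from compound 1 to compound 4 (0.37 log units; beyond the scatter)), and the data offer no measured explanation for either trend.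

On these data alone, whether a chloro group, a hydroxyl group or an amine at this carbon would fit the same order remains open. Also open, as far as these compounds go, is whether the order would hold with heptyl in place of 4-bromophenyl.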